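A Second Chloro on the Benzylidene Ring

A few compounds are considered here, and "the series" means these few. Any claim that something is new, unique, unknown or untested is made for them only; others in the source may bear on it.

Compound 2 `O=C1NC(=S)/C(=C/c2ccccc2Cl)S1`: -11.3%
Compound 1 `O=C1NC(=S)/C(=C/c2ccc(Cl)cc2)S1`: 0.92%

Compound 2 `O=C1NC(=S)/C(=C/c2ccccc2Cl)S1` stands lowest of the two numbers in a functional assay on HEp-2 cells (Homo sapiens) for cytotoxicity, read by MTT assay, with a stated time of 72 h, tested at 1.25 ug/mL; a higher number here means more inhibition of growth at the concentration tested, a lower number less inhibition of growth; compound 1 `O=C1NC(=S)/C(=C/c2ccc(Cl)cc2)S1` lies higher by a gap beyond the scatter, though neither shows much growth inhibition. Compound 3 `O=C1NC(=S)/C(=C/c2ccc(Cl)cc2Cl)S1` differs from compound 2 by chloro in place of hydrogen on an aromatic carbon. With both measured compounds near zero, no step beyond the scatter is expected in this assay. The estimate for compound 3 is -2%, ranging from -16% to 14%, which would be a step of a number 9.3 percentage points higher from compound 2 to compound 3 (within the scatter).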

Compound 3, percent growth inhibition at one concentration: 6.83%
Compound 3: the middle estimate sits 8.8 percentage points below what was measured; low and high end bracket the measured number.
By their numbers in this assay, from the lowest: compound 2; then compounds 1 and 3 (each within the scatter of the next).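

In this assay, the step of a number 18.1 percentage points higher from compound 2 to compound 3 (beyond the scatter) shows that chloro in place of hydrogen on this aromatic carbon, meta to a chloro group and para to a group of 8 heavy atoms, moves the number beyond the scatter. Adding chloro to the other parent instead gives a number 5.9 percentage points higher from compound 1 to compound 3 (within the scatter), so the same kind of change is readable from only one of the two parents. Nothing available explains this difference. From the compounds shown here alone, whether an amine or a carboxylic acid at this position would behave like chloro stays open. So does the behaviour of all three compounds at other concentrations.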